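The source may hold more compounds than are shown below. What is called first, only, known or untested is meant among the compounds shown, and "the series" means these compounds.

Compound 1, with the structure `O=C(/C=C/c1ccc2c(c1)B(O)OC2)c1ccco1`, is tested in a toxicity assay on MCF-10A cells (Homo sapiens) for cytotoxicity, read by MTT assay, with a stated time of 48 h (on this read-out lower numbers stand for stronger inhibition and higher numbers for weaker inhibition), where compound 1 gives 7400 nM as its number. Among the two numbers known, this is the lowest. The nearest is compound 3, with the structure `O=C(/C=C/c1ccc2c(c1)B(O)OC2)c1cccc(F)c1`, for which compound 3 gives 15800 nM in this assay; the step between them is a 2.1-fold higher number from compound 1 to compound 3 (0.33 log units; beyond the scatter) and comes from a 3-fluorophenyl in place of the furan-2-yl on the carbonyl carbon. Compound 2, with the structure `O=C(/C=C/c1ccc2c(c1)B(O)OC2)c1ccc(I)cc1`, has a 4-iodophenyl in that place. For compound 2 only a limit, > 100000 nM, is reported, with no number behind it (the limit of > 100000 nM in this assay, at which 1 of the 3 values shown sits). The step from compound 1 to compound 2 is an at least 13-fold higher number from compound 1 to compound 2 (1.13 log units; beyond the scatter) and the step onward is an at least 6.3-fold lower number from compound 2 to compound 3 (0.80 log units; beyond the scatter) in size.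

Compound 4, with the structure `Nc1cccc(C(=O)/C=C/c2ccc3c(c2)B(O)OC3)c1`, is not yet measured. Within the data shown here, its single difference from compound 1 is 3-aminophenyl in place of furan-2-yl on a carbonyl carbon and nothing else changes. Both measured replacements of the furan-2-yl raised the number, one modestly and one by a large amount, so a higher number is expected for compound 4 too, somewhere between those outcomes. Compound 4 is therefore estimated at 20000 nM, within 6000 nM to 70000 nM, which means an expected step of a 2.7-fold higher number from compound 1 to compound 4 (0.43 log units; beyond the scatter) in this assay.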

Compound 4, half-maximal inhibitory concentration: 19600 nM
The estimate for compound 4 lay 1.0-fold (0.01 log units) above the measured number; measured number inside the range.
By their numbers in this assay, from the lowest: compound 1; then compounds 3 and 4 (each within the scatter of the next). At a limit, above all of these: compound 2.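

In this assay, 3-aminophenyl and 3-fluorophenyl on the carbonyl carbon cannot be told apart: the exchange of fluoro for amino on the aromatic carbon gives a 1.2-fold higher number from compound 3 to compound 4 (0.09 log units; within the scatter), even though 3-aminophenyl carries a hydrogen-bond donor. The move away from furan-2-yl gives a 2.6-fold higher number from compound 1 to compound 4 (0.42 log units; beyond the scatter), so all three replacements shown now give a higher number or a limit, and compound 1 keeps the lowest number of the four. Compared with the 4-iodophenyl group, the new group gives an at least 5.1-fold lower number from compound 2 to compound 4 (0.70 log units; beyond the scatter), a step that is only a bound, as compound 2 is reported as a limit and not as a number: the limit of > 100000 nM in this assay, at which 1 of the 4 values shown sits.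

The compounds shown leave open whether the large step with the 4-iodophenyl group comes from the iodine itself or from where it sits on the ring, and a 3-iodophenyl group would separate these two. They also leave open whether the lower number of compound 1 belongs to five-membered aromatic rings in general or to furan-2-yl alone, which a thiophen-2-yl group could test.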